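This account rests on a few compounds, and the source may have more. Where it says the series, first, only, none or still open, it means among the compounds named here.

Among the compounds with values here, in a functional assay on DU-145 cells (Homo sapiens) for cytotoxicity, read by MTT assay, with a stated time of 48 h (on this read-out higher numbers stand for weaker inhibition and lower numbers for stronger inhibition), the compounds tested so far leave little to compare. Compound 1 `COc1ccc(/C=C/C(=O)/C=C/c2cc3ccccc3nc2Cl)c(OC)c1` gives > 10000 nM, which is a limit of the assay and not a number. Compound 2 `COc1ccc(/C=C/C(=O)/C=C/c2cc3ccccc3nc2Oc2ccccc2)cc1` gives > 10000 nM, again a limit. On these data alone, compound 3 `COc1ccc(/C=C/C(=O)/C=C/c2cc3ccccc3nc2Oc2ccccc2)c(OC)c1` gives > 10000 nM, also only a limit, so its true place on the scale is unknown. The whole picture so far is the limit of > 10000 nM in this assay, at which 3 of the 3 values shown sit.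

Compound 4 `COc1cc(OC)c(OC)cc1/C=C/C(=O)/C=C/c1cc2ccccc2nc1Oc1ccccc1` differs from compound 3 by a single change, methoxy in place of hydrogen on an aromatic carbon. Within the data shown here, the closest precedent is the same kind of change, seen in a step that the two limits leave unreadable from compound 2 to compound 3. Phenoxy in place of chloro gives a step that the two limits leave unreadable from compound 1 to compound 3. Neither step has a readable size, and neither shows any gain in inhibition.

On the precedent of a step that the two limits leave unreadable from compound 2 to compound 3, no clear gain is expected, and the expected change is a step that the limit leaves unreadable from compound 3 to compound 4. Compound 4 is estimated at 12000 nM, with an expected range of 3000 nM to 40000 nM.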

Compound 4, half-maximal inhibitory concentration: 9220 nM
Compound 4: the middle estimate sits 1.3-fold (0.11 log units) above what was measured; low and high end bracket the measured number.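

In this assay compound 4 gives 9220 nM, the first result shown here that is a true number. Compound 3 gives > 10000 nM, which is a limit of the assay and not a number. With methoxy on the aromatic carbon that is ortho to a methoxy group and para to a methoxy group, the result is an at least 1.0-fold lower number from compound 3 to compound 4 (0.03 log units; that floor lies within the scatter), and as the earlier steps cannot be read, this small floor is the only size available for this change, with no clear gain shown.

On these data alone, it remains open whether another group at this position, such as an amine or a longer chain, would give a number clearly apart from that of compound 4. Comparison across the series also remains narrow, with most values still sitting at one limit: the limit of > 10000 nM in this assay, at which 3 of the 4 values shown sit.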